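The source may hold more compounds than are shown below. What is called first, only, known or untested is meant among the compounds shown, and "the series" means these compounds.

Compound 1 `O=C(CCCCC(S)CCS)NO`: 5.96%
Compound 2 `O=C(CCCCC1CCSS1)Nc1ccccc1Cl`: 6.83%
Compound 3 `O=C(CCCCC1CCSS1)Nc1ccc([N+](=O)[O-])c(C(F)(F)F)c1`: 5.04%

In a functional assay on Bel-7402 cells (Homo sapiens) for inhibition, read by MTT assay, with a stated time of 24 h, tested at 0.1 ug/mL (a lower number here means less inhibition of growth, a higher number more inhibition of growth at the concentration tested), compound 1 stands within the scatter of both compound 2 and compound 3, so the three values set no order among these compounds. Compound 4 `O=C(CCCCC(S)CCS)Nc1ccccc1` has phenyl in place of hydroxy on an amide-type nitrogen. No measured pair isolates this change, so its effect has not been shown directly. Compound 2 and compound 3 also show no hydroxy on that nitrogen, and their values stay close to that of compound 1. No step beyond the scatter is therefore expected in this assay. The expected change is a number 0 percentage points higher from compound 1 to compound 4 (within the scatter). Compound 4 is estimated at 6%, with an expected range from 0% to 15%.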

Compound 4, percent growth inhibition at one concentration: 0.85%
Estimate against measurement, compound 4: 5.2 percentage points above; the measured number falls inside the stated range.
By their numbers in this assay, from the lowest: compounds 4, 3, 1 and 2 (each within the scatter of the next).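

In this assay, among these compounds, the swap of phenyl for hydroxy on an amide-type nitrogen gives a number 5.1 percentage points lower from compound 1 to compound 4 (within the scatter) and is the first change here read in a single place. Placing a six-membered aromatic ring of carbon at this position in the core of compound 1 therefore shows no step beyond the scatter at the concentration tested. Nothing measured here bears on why the number for this change falls where it does.

The compounds shown leave open whether an amine or a longer chain on that nitrogen would stay as close to compound 1. They also leave open whether a chlorine on the phenyl of compound 4 would alter the number.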